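The source may hold more compounds than are shown below. What is called first, only, known or untested is meant among the compounds shown, and "the series" means these compounds.

Compound 2 (`Cn1c(=O)c(S(=O)(=O)c2ccc(Cl)cc2)cc2cnc(Nc3ccc4[nH]ccc4c3)nc21`) gives 250 nM in a functional assay on DU-145 cells (Homo sapiens) for inhibition, read by trypan blue exclusion, with a stated time of 72 h (on this read-out lower numbers stand for stronger inhibition and higher numbers for weaker inhibition), and stands lowest of the three measured numbers, with compound 1 (`COc1ccc(Nc2ncc3cc(S(=O)(=O)c4ccc(Cl)cc4)c(=O)n(C)c3n2)cc1`) at 30000 nM and compound 3 (`Cn1c(=O)c(S(=O)(=O)Nc2ccc(F)cc2)cc2cnc(Nc3ccc4[nH]ccc4c3)nc21`) at 5000 nM in the same read-out. Compound 4 (`Cn1c(=O)c(S(=O)(=O)c2ccc(Cl)cc2)cc2cnc(Nc3cccc4[nH]ccc34)nc21`) is unmeasured and differs from compound 2 by one change (1H-indol-4-yl in place of 1H-indol-5-yl on a nitrogen on an aromatic ring) with 1H-indol-4-yl in place of 1H-indol-5-yl on a nitrogen on an aromatic ring. Measured at that nitrogen is a 120-fold lower number from compound 1 to compound 2 (2.08 log units; beyond the scatter) for 1H-indol-5-yl in place of 4-methoxyphenyl. At the sulfonyl sulfur, a 20-fold higher number from compound 2 to compound 3 (1.30 log units; beyond the scatter) bears less directly. Going by the values given here, no measured step isolates this shift, so a moderate rise in this assay is expected rather than a step of the full size seen for compound 2 against compound 1. Compound 4 is estimated at 1000 nM within a range of 200 nM to 5000 nM on this reasoning. The expected shift is a 4.0-fold higher number from compound 2 to compound 4 (0.60 log units; beyond the scatter) as an estimate.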

Compound 4, half-maximal inhibitory concentration: 5000 nM
Compound 4: middle estimate off by 5.0-fold (0.70 log units), on the low side, and the stated range covers the measured number.
By their numbers in this assay, from the lowest: compound 2; then compounds 3 and 4 (each within the scatter of the next); then compound 1.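

In this assay, 1H-indol-4-yl in place of 1H-indol-5-yl, with the same atoms joined differently, gives a 20-fold higher number from compound 2 to compound 4 (1.30 log units; beyond the scatter), so on this nitrogen the point of attachment of the indole counts, not only its presence. Against 4-methoxyphenyl, 1H-indol-4-yl gives a 6.0-fold lower number from compound 1 to compound 4 (0.78 log units; beyond the scatter), a smaller gain than a 120-fold lower number from compound 1 to compound 2 (2.08 log units; beyond the scatter). No available evidence accounts for this difference. From the compounds shown here alone, whether 1H-indol-6-yl on the same nitrogen would sit nearer compound 2 or compound 4 stays open. Also open, going by these compounds, is whether the order of the two indoles holds with (4-fluorophenyl)amino on the sulfonyl sulfur.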